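The source may report more compounds than this note shows. Statements on the series, on what has been measured and on what is new or still open speak of the compounds shown alone.

Measured in a functional assay on MCF7 cells (Homo sapiens) for antiproliferative activity, read by sulforhodamine B assay, with a stated time of 48 h; a lower number here means a stronger inhibitor, a higher number a weaker inhibitor:
compound 1 `COc1ccc(-c2ccccc2C(=O)/C=C/c2ccc(F)cc2)cc1OC` — 7100 nM
compound 2 `COc1ccc(/C=C/C(=O)c2ccccc2-c2ccc(OC)c(OC)c2)cc1OC` — 4900 nM
compound 3 `COc1ccc(-c2ccccc2C(=O)/C=C/c2ccc(Br)cc2)cc1OC` — 8300 nM

Compound 2 gives the lowest of the three numbers, yet its separation from compound 1 a 1.4-fold lower number from compound 1 to compound 2 (0.16 log units; within the scatter) and from compound 3 a 1.7-fold higher number from compound 2 to compound 3 (0.23 log units; within the scatter) both lie within the scatter, so no ordering among them is claimed. Compound 4 `COc1ccc(/C=C/C(=O)c2ccccc2-c2cccc(F)c2)cc1OC` arises from compound 2 by a change on the aromatic ring bound to the core: 3-fluorophenyl in place of 3,4-dimethoxyphenyl on an aromatic carbon. The most relevant measured steps, compound 1 to compound 2 a 1.4-fold lower number from compound 1 to compound 2 (0.16 log units; within the scatter) and compound 2 to compound 3 a 1.7-fold higher number from compound 2 to compound 3 (0.23 log units; within the scatter), replace this same ring with or without a halogen and stay within the scatter. Compound 4 is therefore expected to show little movement beyond the scatter, with the number estimated slightly higher than compound 2, a 1.4-fold higher number from compound 2 to compound 4 (0.15 log units; within the scatter). The estimate for compound 4 in this assay is 7000 nM, within 3500 nM to 14000 nM.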

Compound 4, half-maximal inhibitory concentration: 1200 nM
Beside the measured number, compound 4's estimate is 5.8-fold (0.77 log units) above it; the whole stated range lies above it.
By their numbers in this assay, from the lowest: compound 4; then compounds 2, 1 and 3 (each within the scatter of the next).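

In this assay, within the data shown here, the aromatic carbon ortho to a large group gives the first step beyond the scatter: with 3-fluorophenyl in place of 3,4-dimethoxyphenyl, there is a 4.1-fold lower number from compound 2 to compound 4 (0.61 log units; beyond the scatter). The earlier steps shown here, all at the double-bonded chain carbon, stayed within the scatter, so this position responds where that one did not. Nothing available accounts for this step.

Going by these compounds, it remains open whether the step follows from the fluoro group or from the loss of the methoxy groups. A plain phenyl or a 3-aminophenyl at this position would bear on that question.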